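The compounds below may be only part of what the source reports. "The series", "measured", "known", "first", "only" and "open" are said of these compounds alone.

Measured compounds:
Compound 1 `Cc1ccc(C)c(-n2nncc2CN2C(=O)C3(C(C#N)=C(N)Oc4c3c3nc5ccccc5nc3c3ccccc43)c3ccccc32)c1` gives in a functional assay on MCF7 cells (Homo sapiens) for antiproliferative activity, read by MTT assay, with a stated time of 48 h (on this read-out lower numbers stand for stronger inhibition and higher numbers for weaker inhibition), the value > 50000 nM, which is a limit of the assay rather than a number.
Compound 2 `Cc1cc(C)cc(-n2nncc2CN2C(=O)C3(C(C#N)=C(N)Oc4c3c3nc5ccccc5nc3c3ccccc43)c3ccccc32)c1` gives in this assay the value > 50000 nM, again a limit and not a number.
Compound 3 `COc1ccc(-n2nncc2CN2C(=O)C3(C(C#N)=C(N)Oc4c(N)cc5nc6ccccc6nc5c43)c3ccccc32)cc1` gives in this assay the value > 50000 nM, also a limit and not a number.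

On the numbers shown, compound 3 sits at the limit, and the two other values shown sit at the same limit, (the limit of > 50000 nM in this assay, at which 3 of the 3 values shown sit). Going by the values given here, no compound in this set yielded a number. Among the compounds with values here, the single step between measured compounds, a step that the two limits leave unreadable from compound 1 to compound 2, has no readable size; both of its ends are limits.

Compound 4 `COc1ccc(OC)c(-n2nncc2CN2C(=O)C3(C(C#N)=C(N)Oc4c(N)cc5nc6ccccc6nc5c43)c3ccccc32)c1` has not yet been measured. It differs from compound 3 by 2,5-dimethoxyphenyl in place of 4-methoxyphenyl on an aromatic nitrogen. Within the data shown here, no measured step involves a change of this kind, and the one measured step is unreadable, so there is no basis for expecting a shift of any particular size or direction in this assay beyond the scatter. The expected step is a number no higher from compound 3 to compound 4 (the limit leaves the size open), which amounts to no change beyond the scatter. Compound 4 is therefore estimated to come back at 50000 nM, with an expected range from 20000 nM to 120000 nM, most probably again as a limit rather than a number.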

Compound 4, half-maximal inhibitory concentration: 28100 nM
Compound 4: middle estimate off by 1.8-fold (0.25 log units), on the high side; low and high end bracket the measured number.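

In this assay, going by these compounds alone, the substituent on the aromatic nitrogen of the five-membered ring can give a readable number: compound 4, with 2,5-dimethoxyphenyl, is the only compound here that returns a number rather than a limit. On these data alone, replacing 4-methoxyphenyl with 2,5-dimethoxyphenyl gives an at least 1.7-fold lower number from compound 3 to compound 4 (0.25 log units; that floor lies within the scatter); one end of this step is a limit, so its true size remains unknown and it cannot be said to exceed the usual scatter, unlike the step between the two dimethylphenyl compounds, which cannot be read at all. Activity in this set remains weak, with most values still at the ceiling: the limit of > 50000 nM in this assay, at which 3 of the 4 values shown sit.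

The compounds shown do not reveal whether the added methoxy group alone accounts for the number, since a 2-methoxyphenyl or 3-methoxyphenyl group on the same core would be needed to separate the two methoxy groups. They also leave open how a plain phenyl ring, or a phenyl ring carrying an amine or a carboxylic acid, would behave at this position.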